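Cytotoxicity expected after a dioxoimidazolidinyl-to-dioxothiazolidinyl swap

The source may report more compounds than this note shows. Statements on the series, on what has been measured and on what is new or still open speak of the compounds shown alone.

Measured compounds:
Compound 1 `COC(=O)CC1CCN(C[C@H]2CN(c3ccc(-n4cc(-c5ccccn5)cn4)c(F)c3)C(=O)O2)CC1` — in an ADME assay on L02 cells (Homo sapiens) for cytotoxicity, read by MTT assay, with a stated time of 48 h (a lower number here means a stronger inhibitor, a higher number a weaker inhibitor), compound 1 gives only the limit > 400 ug/mL.
Compound 2 `O=C1CNC(=O)N1C[C@H]1CN(c2ccc(-n3cc(-c4ccccn4)cn3)c(F)c2)C(=O)O1` — in this assay compound 2 gives only the limit > 400 ug/mL.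

Compound 2 therefore stands at the limit of this assay, and the step that the two limits leave unreadable from compound 1 to compound 2 cannot be read. Compound 3 `O=C1CSC(=O)N1C[C@H]1CN(c2ccc(-n3cc(-c4ccccn4)cn3)c(F)c2)C(=O)O1` differs from compound 2 by 2,4-dioxo-1,3-thiazolidin-3-yl in place of 2,5-dioxoimidazolidin-1-yl on a saturated chain carbon bound to a saturated ring carbon. Among the measured compounds shown here, no measured step bears on this change with a readable size; the only evidence is the limit of > 400 ug/mL in this assay, at which 2 of the 2 values shown sit, with every value shown sitting at that limit. On these numbers, no step beyond the scatter is expected for this assay in either direction, and compound 3 is estimated to report a limit as well, the expected step being a step that the limit leaves unreadable from compound 2 to compound 3. Compound 3 is thus estimated at 500 ug/mL, with a range from 200 ug/mL to 2000 ug/mL.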

Compound 3, half-maximal inhibitory concentration: > 400 ug/mL
Compound 3: a limit, no number (the forecaster's own chance of this, stated with the estimate: 85%); the middle value does not contradict the limit.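

In this assay compound 3 gives only the limit > 400 ug/mL, so its steps to compound 1 and compound 2 cannot be read. The compounds shown leave open whether exchanging the group on this saturated chain carbon changes the read-out at all: the limit of > 400 ug/mL in this assay, at which 3 of the 3 values shown sit.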